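Trading Trifluoromethyl for Methyl on Compound 1

This account rests on a few compounds, and the source may have more. Where it says the series, first, only, none or still open, it means among the compounds named here.

Compound 1 `O=C(c1ccc(-c2nc(-c3cccc(C(F)(F)F)c3)no2)s1)C(F)(F)F`: 320 nM in an assay for inhibition of histone deacetylase 4 (Homo sapiens); on this read-out higher numbers stand for weaker inhibition and lower numbers for stronger inhibition
Compound 2 `O=C(c1ccc(-c2nnc(-c3ccccc3)o2)s1)C(F)(F)F`: 420 nM in this assay
Compound 3 `CC(C)(C)c1ccc(-c2noc(-c3ccc(C(=O)C(F)(F)F)s3)n2)cc1`: a limit of > 2000 nM in this assay

Of the compounds shown here, three sharing the trifluoroacetyl thiophene portion have been measured in this assay. Compound 1 gives the lower of the two numbers, with compound 2 giving a number that lies within the usual scatter of it, so the two cannot be ranked against each other. Compound 3 gives only a limit of the assay rather than a number: the limit of > 2000 nM in this assay, at which 1 of the 3 values shown sits.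

Compound 4 `Cc1cccc(-c2noc(-c3ccc(C(=O)C(F)(F)F)s3)n2)c1` has not yet been measured. It differs from compound 1 by methyl in place of trifluoromethyl on an aromatic carbon. Going by the values given here, no step between measured compounds isolates this change, so the expectation rests on the neighbouring compounds only. Compound 3, which carries a tert-butyl group on the same ring and gives only a limit, stands at > 2000 nM. Given that, a modest weakening relative to compound 1 seems plausible, though a result within the scatter cannot be excluded. Compound 4 is expected to give 550 nM in this assay, with a likely range from 180 nM to 1800 nM. This corresponds to an estimated step of a 1.7-fold higher number from compound 1 to compound 4 (0.24 log units; within the scatter), expected to be small.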

Compound 4, half-maximal inhibitory concentration: 280 nM
For compound 4 the middle estimate is 2.0-fold (0.29 log units) above the measured one, within the range that was stated.
By their numbers in this assay, from the lowest: compounds 4, 1 and 2 (each within the scatter of the next). At a limit, above all of these: compound 3.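

Methyl in place of trifluoromethyl on an aromatic carbon, meta to a large group, gives a 1.1-fold lower number from compound 1 to compound 4 (0.06 log units; within the scatter) in this assay. Going by these compounds alone, this is the first step that isolates a single change at this position, and it shows that compound 1 and compound 4 cannot be told apart on this read-out, even though a group of 4 heavy atoms gives way to one of 1 heavy atom. None of the evidence available bears on why this exchange leaves the number within the scatter.

As far as these compounds go, whether the position stays this undemanding with an amine, a carboxylic acid or a longer chain in place of methyl remains open, since only these two groups have been compared there. Compound 3 remains a limit of the assay at > 2000 nM, and because it differs from compound 4 in more than one place, the compounds shown do not tell what its tert-butyl group does.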